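A few compounds are considered here, and "the series" means these few. Any claim that something is new, unique, unknown or untested is made for them only; others in the source may bear on it.

In a functional assay on HL-60 cells (Homo sapiens) for activation (on this read-out lower numbers stand for an effect already at smaller amounts and higher numbers for an effect only at larger amounts of compound), compound 2 `C=C1[C@H](O)CC(=C/C=C/C[C@H](C)C[C@@H](C)CCCC(C)(C)O)C[C@H]1O` gives 6 nM, the lower of the two numbers measured, while compound 1 `C=C1[C@H](O)CC(=C/C=C/CCC[C@@H](C)CCCC(C)(C)O)C[C@H]1O` gives 300 nM. Compound 3 `C=C1[C@H](O)CC(=C/C=C/C[C@@H](C)C[C@@H](C)CCCC(C)(C)O)C[C@H]1O` is still unmeasured and differs from compound 2 as follows: the two compounds have the same atoms and bonds and differ only in configuration as drawn: 1 of 5 stereo elements differ; a stereocentre at a saturated chain carbon is drawn R in compound 2 and S in compound 3. Within the data shown here, one measured step bears on this, a 50-fold lower number from compound 1 to compound 2 (1.70 log units; beyond the scatter), which came with a methyl in place of hydrogen on a saturated chain carbon. It is large, but it does not show what the configuration there does. A move to a higher number in this assay is therefore expected, smaller than that step, and the expected change is a 6.7-fold higher number from compound 2 to compound 3 (0.82 log units; beyond the scatter). Compound 3 is estimated at 40 nM, with an expected range of 6 nM to 300 nM.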

Compound 3, half-maximal effective concentration: 300 nM
For compound 3 the middle estimate is 7.5-fold (0.88 log units) below the measured one; the measured number falls inside the stated range.
By their numbers in this assay, from the lowest: compound 2; then compounds 1 and 3 (each within the scatter of the next).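

In this assay the configuration at this saturated chain carbon now proves decisive, with a 50-fold higher number from compound 2 to compound 3 (1.70 log units; beyond the scatter) on the change from R to S alone: the fact that compounds 2 and 3 differ only in the configuration as drawn. Methyl in place of hydrogen, when drawn S, gives no change at the digits printed from compound 1 to compound 3 (within the scatter) and so the methyl as such does not carry the earlier gain; among these compounds, that gain appears only with the R methyl of compound 2. The compounds shown leave open whether an ethyl group or a hydroxyl group at this carbon, drawn R, would keep the low number of compound 2.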